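The source may report more compounds than this note shows. Statements on the series, on what has been measured and on what is new or still open speak of the compounds shown alone.

Compound 1, `CC(C)C[C@H](NC(=O)[C@@H](N)C(C)(C)C)B(O)O`, gives 710 nM in an ADME assay on FSCLL cells (Homo sapiens) for cytotoxicity, read by MTT assay, with a stated time of 24 h; a lower number here means that less compound is tolerated, a higher number that more compound is tolerated. Compound 2, `CC(C)C[C@H](NC(=O)[C@@H](N)[C@@H](C)O)B(O)O`, gives 2500 nM in this assay.

Within the data shown here, of these two numbers compound 2 holds the higher one; the single measured step, a 3.5-fold higher number from compound 1 to compound 2 (0.55 log units; beyond the scatter), separates them. Compound 3, `CNCC(=O)N[C@@H](CC(C)C)B(O)O`, has not yet been measured. It differs from compound 2 by (methylamino)methyl in place of 1-amino-2-hydroxypropyl on a carbonyl carbon. Among the measured compounds shown here, no measured step swaps exactly this group, and the one step seen, a 3.5-fold higher number from compound 1 to compound 2 (0.55 log units; beyond the scatter), altered the substituent on the same carbon and was modest, so a shift of comparable size in either direction would fit, with no firm direction. Compound 3 is therefore estimated at 1500 nM, range 500 nM to 4500 nM. This estimate means that a 1.7-fold lower number from compound 2 to compound 3 (0.22 log units; within the scatter) is expected.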

Compound 3, half-maximal cytotoxic concentration: 160 nM
Estimate against measurement, compound 3: 9.4-fold (0.97 log units) above; measured number outside the range, below it.
By their numbers in this assay, from the lowest: compound 3; then compound 1; then compound 2.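

In this assay, replacing 1-amino-2-hydroxypropyl with (methylamino)methyl on the carbonyl carbon gives a 16-fold lower number from compound 2 to compound 3 (1.19 log units; beyond the scatter) and so marks a large step. Less compound is tolerated after this change, and the group on this carbon can clearly shift the number far more than the modest earlier step did. No measurement available here explains this shift.

On these data alone, the change removes the hydroxyl-bearing branch and adds a methyl on the nitrogen at once, so which alteration matters remains open. A plain aminomethyl group on the same carbonyl carbon could help separate the two.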